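Three Solubility Limits and an Expected Fourth

The source may hold more compounds than are shown below. What is called first, only, known or untested is meant among the compounds shown, and "the series" means these compounds.

Compound 1 `Cc1ccccc1-c1nc(CN2CCC(C(=O)NCCCN3CCC(C(C)C)CC3)CC2)c(C)o1`: in a physicochemical assay for solubility, in phosphate buffer, measured as kinetic solubility, at pH 7.4 (on this read-out lower numbers stand for lower solubility and higher numbers for higher solubility), compound 1 gives > 71 ug/mL, which is a limit of the assay and not a number.
Compound 2 `Cc1ccccc1-c1nc(CN2CCC(C(=O)NCCCN3CCC(C)CC3)CC2)c(C)o1`: in this assay compound 2 gives > 67 ug/mL, again a limit of the assay.
Compound 3 `Cc1ccccc1-c1nc(CN2CCC(C(=O)NCCCN3[C@H](C)CCC[C@@H]3C)CC2)c(C)o1`: in this assay compound 3 gives > 69 ug/mL, also a limit of the assay.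

Compound 3 therefore stands at a limit only, and the two other values shown are likewise limits. The steps among the measured compounds cannot be read: a step that the two limits leave unreadable from compound 1 to compound 2, a step that the two limits leave unreadable from compound 1 to compound 3 and a step that the two limits leave unreadable from compound 2 to compound 3 are all left unreadable by the two limits involved. All that is known is that one value sits at the limit of > 67 ug/mL in this assay, at which 1 of the 3 values shown sits, one at the limit of > 69 ug/mL in this assay, at which 1 of the 3 values shown sits, and one at the limit of > 71 ug/mL in this assay, at which 1 of the 3 values shown sits.

The untested compound 4 `Cc1ccccc1-c1nc(CN2CCC(C(=O)NCCCN3CCCC(CC(C)C)C3)CC2)c(C)o1` differs from compound 3 in one place: a group of 10 heavy atoms (9 carbon, 1 nitrogen; one six-membered non-aromatic ring with 1 hetero atom) in place of a group of 8 heavy atoms (7 carbon, 1 nitrogen; one six-membered non-aromatic ring with 1 hetero atom), on a saturated chain carbon, three bonds along the chain from an amide-type nitrogen. Among the compounds with values here, no measured step bears readably on this change, and the three values shown give no direction beyond the limits themselves. The step of an at least 1.0-fold lower number from compound 3 to compound 4 (0.02 log units; that floor lies within the scatter) is therefore expected to be none beyond the scatter, with a fair chance that the assay again reports only a limit. Compound 4 is estimated to give 65 ug/mL in this assay, with a range from 30 ug/mL to 110 ug/mL.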

Compound 4, solubility: 54.9 ug/mL
For compound 4 the middle estimate is 1.2-fold (0.07 log units) above the measured one; the measured number falls inside the stated range.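

In this assay, within the data shown here, compound 4 gives 54.9 ug/mL, the only one of the four values shown that is a number and not a limit of the assay, with a group of 10 heavy atoms on the saturated chain carbon, three bonds along the chain from an amide-type nitrogen. This number yields an at least 1.2-fold lower number from compound 3 to compound 4 (0.09 log units; that floor lies within the scatter) and an at least 1.2-fold lower number from compound 2 to compound 4 (0.08 log units; that floor lies within the scatter) as well as an at least 1.2-fold lower number from compound 1 to compound 4 (0.11 log units; that floor lies within the scatter) and each of these steps is a floor only, so its full size cannot be told. Among these compounds, the steps among compound 1, compound 2 and compound 3 cannot be read, which leaves these three as the only readable steps at this place, and no floor among them passes the scatter.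

Nothing shown bears on why compound 4 gives a number where the others give limits. On these data alone, how a morpholine ring, an open-chain dialkylamine or a carboxylic acid at this place would read in this assay stays open, as do the true values that lie behind the limits of compound 1, compound 2 and compound 3.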